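This account rests on a few compounds, and the source may have more. Where it says the series, first, only, none or still open, it means among the compounds named here.

Within the data shown here, compound 2 `COc1ccc(CCCCCCCCOc2ccc(C[S+]([O-])c3cccc(N)c3)nc2/C=C/C(=O)O)cc1` gives the lowest number of the two measured so far in an assay for binding affinity to leukotriene B4 receptor 1 (Homo sapiens) (a higher number here means a weaker inhibitor, a lower number a stronger inhibitor), namely 4.7 nM. Among the measured compounds shown here, its nearest neighbour is compound 1 `COc1ccc(CCCCCCCCOc2ccc(CSc3cccc(N)c3)nc2/C=C/C(=O)O)cc1`, which in this assay gives 34 nM; the single measured step is a 7.2-fold lower number from compound 1 to compound 2 (0.86 log units; beyond the scatter). Compound 3 `COc1ccc(CCCCCCCCOc2ccc(CSc3cccc(OC)c3)nc2/C=C/C(=O)O)cc1` is not yet measured. Relative to compound 2 the change is a group of 9 heavy atoms (7 carbon, 1 oxygen, 1 sulfur; one six-membered aromatic ring of carbon only) in place of a group of 9 heavy atoms (6 carbon, 1 nitrogen, 1 oxygen, 1 sulfur; one six-membered aromatic ring of carbon only), on a saturated chain carbon bound to an aromatic carbon. For the measured compounds named here, this change undoes the one measured step, as compound 3 carries the sulfide found in compound 1, and at the same time exchanges the amino-bearing ring for a methoxy-bearing one. Going by the values given here, no measured pair shows how the amino-to-methoxy exchange alone acts in this assay; the only step available, a 7.2-fold lower number from compound 1 to compound 2 (0.86 log units; beyond the scatter), indicates that the return from sulfoxide to sulfide should by itself move the number back toward that of compound 1. The expected step is therefore a 6.4-fold higher number from compound 2 to compound 3 (0.81 log units; beyond the scatter), upward, carrying wide uncertainty from the unmeasured ring exchange. Compound 3 is thus estimated at 30 nM in this assay, within a range of 8 nM to 120 nM.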

Compound 3, inhibition constant: 192 nM
Compound 3: middle estimate off by 6.4-fold (0.81 log units), on the low side, outside the stated range (above it).
By their numbers in this assay, from the lowest: compound 2; then compound 1; then compound 3.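

With the sulfide held constant, the exchange of amino for methoxy on an aromatic carbon can now be read alone in this assay, and it gives a 5.6-fold higher number from compound 1 to compound 3 (0.75 log units; beyond the scatter). The ring exchange therefore runs in the same direction as the return from sulfoxide to sulfide, so the two changes together give a 41-fold higher number from compound 2 to compound 3 (1.61 log units; beyond the scatter), a step classed as large, where the sulfide pair alone shows a modest one. Nothing available explains why the amino-bearing ring gives the lower number in this pair.

As far as these compounds go, because the amino-to-methoxy exchange is read only on the sulfide, it stays open whether a sulfoxide carrying the (3-methoxyphenyl) group would show the same step, and so whether the two changes are independent of each other. Also open, from the compounds shown here alone, is how a hydroxy, methyl or dimethylamino group would compare with amino and methoxy on that aromatic carbon, and whether a sulfone would extend or reverse the step seen from sulfide to sulfoxide.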